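Urea-linked anilinoquinazoline series: amine-bearing aryl variants

The compounds below may be only part of what the source reports. "The series", "measured", "known", "first", "only" and "open" are said of these compounds alone.

For the measured compounds named here, compound 3 `O=C(Nc1cccc(CN2CCCC2)c1)Nc1ccc2ncnc(Nc3cccc(C(F)(F)F)c3)c2c1` gives 1230 nM in a functional assay on A-431 cells (Homo sapiens) for antiproliferative activity, read by MTT assay, with a stated time of 72 h (on this read-out higher numbers stand for weaker inhibition and lower numbers for stronger inhibition), the lowest of the three numbers so far, but within the scatter of both compound 2 `O=C(Nc1ccc(CN2CCCCC2)cc1)Nc1ccc2ncnc(Nc3cccc(C(F)(F)F)c3)c2c1` with 1550 nM and compound 1 `CN1CCN(Cc2ccc(NC(=O)Nc3ccc4ncnc(Nc5cccc(C(F)(F)F)c5)c4c3)cc2)CC1` with 2410 nM. Going by the values given here, the one measured single-point step, a 1.6-fold lower number from compound 1 to compound 2 (0.19 log units; within the scatter), exchanges one saturated amine ring for another on the saturated chain carbon and moves nothing beyond the scatter. Compound 4 `CCN(CC)c1ccc(NC(=O)Nc2ccc3ncnc(Nc4cccc(C(F)(F)F)c4)c3c2)cc1` is the next variant: 4-(diethylamino)phenyl in place of 3-((pyrrolidin-1-yl)methyl)phenyl on an amide-type nitrogen. Among the compounds with values here, no measured step covers loss of the saturated chain carbon or direct attachment of the amine to the aromatic ring, so the only bearing evidence is the indifference of this assay to the amine change from compound 1 to compound 2. On that basis compound 4 is expected to stay near compound 3, with a 1.1-fold higher number from compound 3 to compound 4 (0.06 log units; within the scatter) the estimated step, not beyond the scatter in either direction. The expected value for compound 4 is 1400 nM, with a range from 500 nM to 4000 nM.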

Compound 4, half-maximal inhibitory concentration: 6460 nM
Estimate against measurement, compound 4: 4.6-fold (0.66 log units) below, outside the stated range (above it).
By their numbers in this assay, from the lowest: compounds 3, 2 and 1 (each within the scatter of the next); then compound 4.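

In this assay, the amine substituent on this aryl ring is no longer a matter of indifference: with diethylamino on the aromatic carbon in place of the (piperidin-1-yl)methyl or (4-methylpiperazin-1-yl)methyl groups, the steps are (a 4.2-fold higher number from compound 2 to compound 4 (0.62 log units; beyond the scatter)) and (a 2.7-fold higher number from compound 1 to compound 4 (0.43 log units; beyond the scatter)), and replacing 3-((pyrrolidin-1-yl)methyl)phenyl with 4-(diethylamino)phenyl gives (a 5.3-fold higher number from compound 3 to compound 4 (0.72 log units; beyond the scatter)). All three steps are modest but beyond the scatter, unlike the exchange of one saturated amine ring for another. No measurement bearing on the origin of these steps is available.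

Compound 4 differs from the others by lacking both the saturated chain carbon and a saturated amine ring, so these two features remain unseparated. A (diethylamino)methyl group or a directly attached pyrrolidin-1-yl group on the aromatic carbon would divide them.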